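This account rests on a few compounds, and the source may have more. Where it says the series, first, only, none or still open, it means among the compounds named here.

Working notes on the series, read in a functional assay on HCT-116 cells (Homo sapiens) for inhibition, read by sulforhodamine B assay, with a stated time of 48 h; a higher number here means a weaker inhibitor, a lower number a stronger inhibitor. For the measured compounds named here, compound 1 `COc1ccc(C(c2ccc(OC(C)CN(C)C)cc2)c2cccc3ccccc23)c(OC)c1OC` gives 8410 nM, the only measured number so far. Compound 2 `COc1ccc(C(c2ccc(OCCO)cc2)c2cccc3ccccc23)c(OC)c1OC` stands only at a limit of the assay, > 20000 nM. Compound 3 `CCOC(=O)C(C)C(O)(c1ccc(OC)c(OC)c1OC)c1cccc2ccccc12` also stands only at a limit, > 20000 nM. Together these make up (the limit of > 20000 nM in this assay, at which 2 of the 3 values shown sit).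

Compound 4 `C=CCOC(c1ccc(OC)c(OC)c1OC)c1cccc2ccccc12` has allyloxy in place of the 4-(2-hydroxyethoxy)phenyl of compound 2, on a saturated chain carbon bound to two aromatic carbons: allyloxy in place of 4-(2-hydroxyethoxy)phenyl on a saturated chain carbon bound to two aromatic carbons.

Going by the values given here, no measured step covers this exchange. The nearest is an at least 2.3-fold higher number from compound 1 to compound 2 (0.37 log units; beyond the scatter), a change within the arm that compound 4 loses entirely, and it gives only a lower bound on size. Compound 4 carries no 1-((dimethylamino)methyl)ethyl, the group present in compound 1 at 8410 nM. No step beyond the scatter is therefore expected in this assay, and a limit result is likely. The estimated change is a number no higher from compound 2 to compound 4 (the limit leaves the size open). The expected value for compound 4 is 20000 nM, with an estimated range of 9000 nM to 40000 nM.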

Compound 4, half-maximal inhibitory concentration: > 20000 nM
Compound 4 gave a limit, no number; the forecaster's own chance of this, stated with the estimate: 65%; the middle value lies on the limit itself.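

For the compounds shown here, compound 2 and compound 4 both stand only at a limit in this assay, and no step between them can be read. The compounds shown leave open how far allyloxy and 4-(2-hydroxyethoxy)phenyl differ, since the size of that exchange stays unknown.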